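The source may report more compounds than this note shows. Statements on the series, on what has been measured and on what is new or still open speak of the compounds shown alone.

Measured compounds:
Compound 1, `COc1ccc2c(c1)OCC([C@H](O)/C=C/[C@@H]1C3C/C(=C/CCCC(=O)O)CC3C[C@H]1O)O2`, gives 0.0021 mg/kg.
Compound 2, `O=C(O)CCC/C=C1\CC2C[C@@H](O)[C@H](/C=C/[C@@H](O)C3COC4CCCCC4O3)C2C1`, gives 0.256 mg/kg.

Both were tested in a functional assay on the whole organism (stomach) for inhibition, with Rattus norvegicus as the target; on this read-out lower numbers stand for an effect already at smaller amounts and higher numbers for an effect only at larger amounts of compound. Compound 2 stands at the highest of the two numbers; its nearest neighbour, compound 1, gives a number that is lower by a gap well beyond the usual scatter, so compound 2 is the weaker of the two by a clear margin.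

Compound 3, `CC1([C@H](O)/C=C/[C@@H]2C3C/C(=C/CCCC(=O)O)CC3C[C@H]2O)Cc2ccccc2C1`, has not yet been measured. It differs from compound 2 at a single place: a group of 10 heavy atoms (10 carbon; one five-membered non-aromatic ring of carbon only, one six-membered aromatic ring of carbon only) in place of a group of 10 heavy atoms (8 carbon, 2 oxygen; one six-membered non-aromatic ring of carbon only, one six-membered non-aromatic ring with 2 hetero atoms), on a saturated chain carbon bound to a double-bonded chain carbon and an oxygen on a saturated carbon. The two oxygen atoms of the leaving group are gone, and an aromatic ring appears in the entering group, which compound 1, the stronger compound, also carries at its own side chain, though in a different arrangement.

For the measured compounds named here, with no measured pair showing exactly this change, the expectation rests on the spread between compound 1 and compound 2. The step from compound 2 to compound 3 in this assay is expected to be an 8.5-fold lower number from compound 2 to compound 3 (0.93 log units; beyond the scatter), toward a lower number, but with wide uncertainty. Compound 3 is therefore estimated at 0.03 mg/kg, with a range from 0.004 mg/kg to 0.25 mg/kg.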

Compound 3, dose for half-maximal effect: 0.0452 mg/kg
For compound 3 the middle estimate is 1.5-fold (0.18 log units) below the measured one; measured number inside the range.
By their numbers in this assay, from the lowest: compound 1; then compound 3; then compound 2.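

In this assay, putting 2-methyl-2,3-dihydro-1H-inden-2-yl on the saturated chain carbon in place of the oxygen-bearing group gives a 5.7-fold lower number from compound 2 to compound 3 (0.75 log units; beyond the scatter), a modest step but one beyond the usual scatter, so this position responds to the group it carries and still accepts a group with no oxygen atom at all. Both groups count 10 heavy atoms, so the number moves with that count unchanged, while the hydrogen-bond acceptors of the leaving group disappear and an aromatic ring and a five-membered carbon ring arrive together. No independent measurement is available to explain the change or to assign it to any one of these differences.

Since several features change in this single step, the compounds shown cannot separate the loss of the oxygen atoms from the gain of the aromatic ring. Also open, as far as these compounds go, is how the number would respond to an ethyl group in place of the methyl of the new group, or to a fluorine atom or an amine on its aromatic ring.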